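This account rests on a few compounds, and the source may have more. Where it says the series, first, only, none or still open, it means among the compounds named here.

Of the compounds shown here, two have been tested in a functional assay on the whole organism (strain albino) for inhibition, with Rattus norvegicus as the target, read by paw edema, with a stated time of 2 h, at a dose of 0.28 mmol/kg by the oral route; a lower number here means less inhibition, a higher number more inhibition at the dose given (going by the name of the read-out). Compound 1, with the structure `COc1ccc(-c2nnc(SCC(=O)c3ccccc3)n2-c2ccccc2)cc1OC`, gives 57% in this assay. Compound 2, with the structure `C=CCn1c(SCC(=O)c2ccccc2)nnc1-c1ccc(OC)cc1`, gives 53% in this assay. Compound 2 holds the lower of the two numbers, but the gap to compound 1 is small and lies within the scatter that repeated measurements of this kind usually show, so the two results cannot be told apart with confidence.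

The next compound, compound 3, has the structure `COc1ccc(-c2nnc(SCC(=O)c3ccccc3)n2-c2ccccc2)cc1`. It differs from compound 2 in a single place: phenyl in place of allyl on an aromatic nitrogen.

Among the measured compounds shown here, no pair of measured compounds differing in one place is available, so the size of this kind of step in this assay is unknown. For the measured compounds named here, the only guide is that the two measured compounds, which differ in more than one place, sit within the scatter of each other. On that basis the step of a number 2 percentage points higher from compound 2 to compound 3 (within the scatter) is expected to be no larger than the scatter, in either direction. Compound 3 is therefore expected to give about 55% in this assay, within a range from 40% to 68%.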

Compound 3, a percentage reported as inhibition, in the whole organism at one dose (the size of the read-out at that dose, not a potency): 57%
Compound 3: middle estimate off by 2 percentage points, on the low side, within the range that was stated.
By their numbers in this assay, from the lowest: compounds 2, 1 and 3 (each within the scatter of the next).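

On the aromatic nitrogen, phenyl in place of allyl swaps an open chain with a double bond for a six-membered aromatic ring, yet it gives a number 4 percentage points higher from compound 2 to compound 3 (within the scatter) in this assay, so this large change in the group leaves no difference that can be told from the scatter. On an aromatic carbon of the group next to that nitrogen's ring, hydrogen in place of methoxy gives no change at the digits printed from compound 1 to compound 3 (within the scatter), so the extra methoxy group likewise makes no readable difference in this assay. Nothing measured here offers an explanation for either result.

As far as these compounds go, whether any group on the aromatic nitrogen can move the inhibition beyond the scatter remains open, for instance a chain ending in an amine or a carboxylic acid, since allyl and phenyl are both built of carbon alone. Because each compound is read at a single dose and a single time, these numbers also leave open whether compounds that look alike here would still match at other doses or at other times.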